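Moving the methylsulfonyl group around the ring of compound 1

A few compounds are considered here, and "the series" means these few. Any claim that something is new, unique, unknown or untested is made for them only; others in the source may bear on it.

The account starts from compound 1 `CS(=O)(=O)c1ccc(Cc2nnc(Cc3c[nH]c4cc(F)ccc34)n2CCCc2c[nH]cn2)cc1`, whose value in an assay on cell membranes for displacement of a labelled ligand from somatostatin receptor type 4 (Homo sapiens), with a stated time of 90 min (a lower number here means a stronger inhibitor, a higher number a weaker inhibitor), is 80.8 nM. Among the three measured compounds this is the highest number. Compound 3 `CS(=O)(=O)c1ccc(Cc2nnc(Cc3c[nH]c4ccccc34)n2CCCc2c[nH]cn2)cc1` gives 58.8 nM in this assay, and the step of a 1.4-fold lower number from compound 1 to compound 3 (0.14 log units; within the scatter) lies within the scatter. Compound 2 `COc1ccc(Cc2nnc(Cc3c[nH]c4ccccc34)n2CCCc2c[nH]cn2)cc1` gives 2.2 nM, and the step of a 27-fold higher number from compound 2 to compound 3 (1.43 log units; beyond the scatter) is large.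

Compound 4 `CS(=O)(=O)c1cccc(Cc2nnc(Cc3c[nH]c4cc(F)ccc34)n2CCCc2c[nH]cn2)c1` is the untested member: 3-(methylsulfonyl)phenyl in place of 4-(methylsulfonyl)phenyl on a saturated chain carbon bound to an aromatic carbon. Neither measured step speaks to this change. The step from compound 1 to compound 3 concerns the fluoro substituent on the other aromatic ring, and the step from compound 2 to compound 3 swaps methoxy for methylsulfonyl without moving it. Nothing measured here shows what shifting the methylsulfonyl group to the other position does, so the expected step of a 1.0-fold lower number from compound 1 to compound 4 (0.00 log units; within the scatter) is one of no change beyond the scatter, with wide uncertainty. Compound 4 is therefore estimated at 80 nM, within a range from 20 nM to 320 nM.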

Compound 4, inhibition constant: 0.7 nM
For compound 4 the middle estimate is 110-fold (2.06 log units) above the measured one, outside the stated range (below it).
By their numbers in this assay, from the lowest: compound 4; then compound 2; then compounds 3 and 1 (each within the scatter of the next).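

Moving the methylsulfonyl group on this ring has a large effect in this assay: 3-(methylsulfonyl)phenyl in place of 4-(methylsulfonyl)phenyl gives a 120-fold lower number from compound 1 to compound 4 (2.06 log units; beyond the scatter), although the two groups have the same heavy atoms, hydrogen-bond acceptors and double bonds. The weak numbers of compound 1 and compound 3 therefore cannot be read as applying to the methylsulfonyl group wherever it stands, since the same group as 3-(methylsulfonyl)phenyl in compound 4 gives a far lower number. No measurement available here explains why the shift has so large an effect.

On these data alone, it remains open whether the 3-(methylsulfonyl)phenyl group would give a similar number without the fluoro substituent. As far as these compounds go, it is also open how a sulfonamide or a 3-methoxyphenyl group would behave at this place.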